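Two measured compounds and one expected value

The source may hold more compounds than are shown below. What is called first, only, known or untested is meant among the compounds shown, and "the series" means these compounds.

Compound 1 `COc1cc(OC)cc(-c2cn(-c3ccc(O)c(C(=O)O)c3)nn2)c1`: 2%
Compound 2 `COc1ccc(OC)c(-c2cn(-c3ccc(O)c(C(=O)OCCCc4ccccc4)c3)nn2)c1`: 13%

Both measured compounds share a core and were tested in a functional assay on HCT-116 cells (Homo sapiens) for inhibition, read by MTT assay, with a stated time of 2 days, tested at 10 uM; a higher number here means more inhibition at the concentration tested (going by the name of the read-out), a lower number less inhibition. In this assay compound 1 gives 2%. In this assay compound 2 gives 13%. Among the compounds with values here, of the two numbers, compound 2 stands highest; its only neighbour, compound 1, lies lower by a gap that is beyond the usual scatter, so the two are distinguishable.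

Compound 3 `COc1ccc(-c2cn(-c3ccc(O)c(C(=O)OCCCc4ccccc4)c3)nn2)cc1` is not yet measured. It differs from compound 2 in one place: 4-methoxyphenyl in place of 2,5-dimethoxyphenyl on an aromatic carbon. Within the data shown here, no measured pair shows a change of this kind, so nothing measured says how much this difference is worth. The expectation therefore rests on compound 2 alone and on the fact that both aryl groups keep a methoxy substituent. The step from compound 2 to compound 3 is expected to be small, most likely no change beyond the scatter or a modest drop: a number 5 percentage points lower from compound 2 to compound 3 (within the scatter). For compound 3 the estimated value is 8%, with a range from 0% to 20%.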

Compound 3, a percentage reported as inhibition, at one concentration (the size of the read-out at that concentration, not a potency): 12%
For compound 3 the middle estimate is 4 percentage points below the measured one, and the stated range covers the measured number.
By their numbers in this assay, from the lowest: compounds 1, 3 and 2 (each within the scatter of the next, the first and the last beyond it).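

In this assay, within the data shown here, placing 4-methoxyphenyl where 2,5-dimethoxyphenyl stood, on the aromatic carbon of the five-membered aromatic ring with 3 nitrogen, gives a number 1 percentage points lower from compound 2 to compound 3 (within the scatter), the first step in this set that isolates a single place. At this position, therefore, the two aryl groups cannot be told apart at the concentration tested, although they differ in both the number and the arrangement of their methoxy groups. There is no independent evidence to explain this result.

On these data alone, the two aryl groups both carry methoxy substituents, so it remains open whether an unsubstituted phenyl, a ring bearing an amine or a carboxylic acid, or a pyridine ring at this position would shift the reading beyond the scatter. As far as these compounds go, compound 2 and compound 3 also share the same ester, so what a methyl ester or a longer chain at that site would do remains unknown, as does whether the flat result for this aryl change would hold with a different ester in place.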